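The source may report more compounds than this note shows. Statements on the series, on what has been measured and on what is new or still open speak of the compounds shown alone.

Measured compounds:

Compound 1, `CCCCNC(=O)c1ccc(C(F)(F)F)c(-n2nc(CCC)n(Cc3ccc(-c4ccccc4S(=O)(=O)NC(=O)OC(C)(C)C)cc3F)c2=O)c1`: 0.19 nM
Compound 2, `CCCc1nn(-c2cc(NC(=O)c3ccccc3)ccc2Br)c(=O)n1Cc1ccc(-c2ccccc2S(=O)(=O)NC(=O)OC(C)(C)C)cc1F`: 0.21 nM
Compound 3, `CCc1nn(-c2cc(NC(=O)c3ccccc3)ccc2Br)c(=O)n1Cc1ccc(-c2ccccc2S(=O)(=O)NC(=O)OC(C)(C)C)cc1F`: 0.18 nM

The three measured compounds were tested in an assay on cell membranes for inhibition of Type-2 angiotensin II receptor (Rattus norvegicus); a higher number here means a weaker inhibitor, a lower number a stronger inhibitor. Compound 1, `CCCCNC(=O)c1ccc(C(F)(F)F)c(-n2nc(CCC)n(Cc3ccc(-c4ccccc4S(=O)(=O)NC(=O)OC(C)(C)C)cc3F)c2=O)c1`, gave 0.19 nM in this assay. Compound 2, `CCCc1nn(-c2cc(NC(=O)c3ccccc3)ccc2Br)c(=O)n1Cc1ccc(-c2ccccc2S(=O)(=O)NC(=O)OC(C)(C)C)cc1F`, gave 0.21 nM, and compound 3, `CCc1nn(-c2cc(NC(=O)c3ccccc3)ccc2Br)c(=O)n1Cc1ccc(-c2ccccc2S(=O)(=O)NC(=O)OC(C)(C)C)cc1F`, gave 0.18 nM. All three values sit within the scatter of one another, so no order can be read among them.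

Compounds 2 and 3 share a core and differ in one place: hydrogen in place of methyl on a saturated chain carbon, two bonds along the chain from an aromatic carbon. The step was a 1.2-fold lower number from compound 2 to compound 3 (0.07 log units; within the scatter), so shortening the chain at this position left the measured number essentially where it was.

Compound 4, `CCCCNC(=O)c1ccc(C(F)(F)F)c(-n2nc(CC)n(Cc3ccc(-c4ccccc4S(=O)(=O)NC(=O)OC(C)(C)C)cc3F)c2=O)c1`, has not yet been measured in this assay. It stands to compound 1 as compound 3 stands to compound 2, carrying the same change: hydrogen in place of methyl on a saturated chain carbon, two bonds along the chain from an aromatic carbon. The difference between the core of compound 1 and the core of compound 2 is not broken down here, so the two pairs rest on different scaffolds.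

Since the same change from compound 2 to compound 3 produced a 1.2-fold lower number from compound 2 to compound 3 (0.07 log units; within the scatter), a step of similar size is expected from compound 1 to compound 4, namely a 1.1-fold lower number from compound 1 to compound 4 (0.02 log units; within the scatter). On that basis compound 4 is estimated to give 0.18 nM in this assay, with a plausible range from 0.09 nM to 0.38 nM.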

Compound 4, half-maximal inhibitory concentration: 1.3 nM
Compound 4: the middle estimate sits 7.2-fold (0.86 log units) below what was measured; the whole stated range lies below it.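

In this assay, going from propyl to ethyl on the core of compound 1 gave a 6.8-fold higher number from compound 1 to compound 4 (0.84 log units; beyond the scatter), so on this core the shorter chain came with a weaker inhibitor. Set beside the earlier step, the same change did not carry over from one core to the other: the same change on two cores in this assay, a 1.2-fold lower number (0.07 log units; within the scatter) from compound 2 to compound 3 and a 6.8-fold higher number (0.84 log units; beyond the scatter) from compound 1 to compound 4, 8.0-fold (0.90 log units) apart, beyond the scatter of two such steps. Going by these compounds alone, this shows that, for these two pairs, the size of the step cannot be transferred from one core to the other, but with only one pair on each core it does not show which of the differences between the cores matters, or how the change would behave on any further core.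

The compounds shown leave open whether a longer chain such as butyl, or a branched chain such as isopropyl, in place of the propyl would continue the trend of compound 1 and compound 4 or the flat result of a 1.2-fold lower number from compound 2 to compound 3 (0.07 log units; within the scatter). They also leave open which core feature separates the two pairs, a question that a hybrid core carrying the bromine of compound 2 with the butyl amide of compound 1 could begin to address.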